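From propyl to ethyl on the shared core

This account rests on a few compounds, and the source may have more. Where it says the series, first, only, none or still open, it means among the compounds named here.

Measured in an ADME assay on MT4 cells (Homo sapiens) for cytotoxicity, read by MTT assay; a higher number here means that more compound is tolerated, a lower number that less compound is tolerated:
- compound 1 `Cc1ccc(CC2C(=O)N(O)C(=O)c3ccccc32)cc1`: 5500 nM
- compound 2 `CCCC1C(=O)N(O)C(=O)c2ccccc21`: 25400 nM
- compound 3 `O=C1c2ccccc2C(CCc2ccccc2)C(=O)N1O`: 30000 nM

Compound 2 and compound 3 lie level, with a 1.2-fold higher number from compound 2 to compound 3 (0.07 log units; within the scatter). Both stand clear of compound 1, with a 4.6-fold higher number from compound 1 to compound 2 (0.66 log units; beyond the scatter) and a 5.5-fold higher number from compound 1 to compound 3 (0.74 log units; beyond the scatter). Compound 4 `CCC1C(=O)N(O)C(=O)c2ccccc21` departs from compound 2 by hydrogen in place of methyl on a saturated chain carbon, two bonds along the chain from a saturated ring carbon. The step from compound 2 to compound 3 changes that same place and stays within the scatter, whereas the larger steps from compound 1 change a different one. No step beyond the scatter is therefore expected in this assay, the estimate being a 1.1-fold higher number from compound 2 to compound 4 (0.03 log units; within the scatter). The expected value for compound 4 is 27000 nM, within a range of 13000 nM to 55000 nM.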

Compound 4, half-maximal cytotoxic concentration: 250000 nM
Compound 4: the middle estimate sits 9.3-fold (0.97 log units) below what was measured; the whole stated range lies below it.
By their numbers in this assay, from the lowest: compound 1; then compounds 2 and 3 (each within the scatter of the next); then compound 4.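

In this assay the change from propyl to ethyl gives a 9.8-fold higher number from compound 2 to compound 4 (0.99 log units; beyond the scatter) on the shared core, although phenyl in place of methyl at this same place left the number level, so this place does not answer alike to every change. Compound 4 also stands clear of the other two compounds, with an 8.3-fold higher number from compound 3 to compound 4 (0.92 log units; beyond the scatter) and with a 45-fold higher number from compound 1 to compound 4 (1.66 log units; beyond the scatter) as the largest step shown. Nothing available here explains the size of these steps.

As far as these compounds go, whether a methyl group, a butyl chain or an amine at this place would keep the number this high remains open. So does whether the step follows chain length alone.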